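This account rests on a few compounds, and the source may have more. Where it says the series, first, only, none or still open, it means among the compounds named here.

Of the compounds shown here, three that share one core have so far been measured in a functional assay on HeLa cells (Homo sapiens) for antiproliferative activity, with a stated time of 24 h; a lower number here means a stronger inhibitor, a higher number a weaker inhibitor. Compound 1 `NC(=O)c1c(NC(=O)c2ccccc2Cl)sc2c1CCNC2` gives 45000 nM. Compound 2 `NC(=O)c1c(NC(=O)c2ccccc2Cl)sc2c1CCN(Cc1ccccc1)C2`, which carries a benzyl group on the ring nitrogen, gives 38400 nM, and compound 3 `NC(=O)c1c(NC(=O)c2ccccc2Cl)sc2c1CCN(Cc1ccccc1Cl)C2` gives 27500 nM. Compound 3 stands at the lowest of the three numbers, yet the steps of a 1.6-fold lower number from compound 1 to compound 3 (0.21 log units; within the scatter) and a 1.4-fold lower number from compound 2 to compound 3 (0.14 log units; within the scatter) are both within the scatter, as is a 1.2-fold lower number from compound 1 to compound 2 (0.07 log units; within the scatter), so the three compounds cannot be told apart in this assay.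

Compound 4 `NC(=O)c1c(NC(=O)c2ccccc2Cl)sc2c1CCN(Cc1ccc([N+](=O)[O-])cc1)C2` has not yet been measured. It differs from compound 3 by 4-nitrophenyl in place of 2-chlorophenyl on a saturated chain carbon bound to an amine nitrogen in a ring. Among the compounds with values here, the steps that bear on this change are the three already seen: each alters either the group on the ring nitrogen or a substituent on its benzyl ring, and none of them moves this assay beyond the scatter. Within the data shown here, the exchange of 2-chlorobenzyl for 4-nitrobenzyl is a change of the same kind, although no measured step swaps one aromatic substituent for another. Compound 4 is therefore expected to give a number close to that of compound 3, with an expected step of a 1.0-fold higher number from compound 3 to compound 4 (0.01 log units; within the scatter) that stays within the scatter. The estimate for compound 4 in this assay is 28000 nM, between 12000 nM and 65000 nM.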

Compound 4, half-maximal inhibitory concentration: 46100 nM
Estimate against measurement, compound 4: 1.6-fold (0.22 log units) below; low and high end bracket the measured number.
By their numbers in this assay, from the lowest: compounds 3, 2, 1 and 4 (each within the scatter of the next).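

Within the data shown here, exchanging 2-chlorophenyl for 4-nitrophenyl on a saturated chain carbon bound to an amine nitrogen in a ring is the first swap of one substituted aromatic group for another here, and in this assay it gives a 1.7-fold higher number from compound 3 to compound 4 (0.22 log units; within the scatter). Adding a nitro group to the plain benzyl group gives a 1.2-fold higher number from compound 2 to compound 4 (0.08 log units; within the scatter), and the whole 4-nitrobenzyl group in place of hydrogen on the ring nitrogen gives a 1.0-fold higher number from compound 1 to compound 4 (0.01 log units; within the scatter), so hydrogen, benzyl, 2-chlorobenzyl and 4-nitrobenzyl at this position cannot be told apart in this assay. Nothing measured on these compounds offers an explanation for these numbers.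

The compounds shown leave open whether any group at this position can move the number beyond the scatter, such as a longer chain between the ring nitrogen and the phenyl ring, or an amine or a carboxylic acid on that phenyl ring. Going by these compounds, the rest of the shared core is the same in all four compounds, so the effect of a change there also remains open.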